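Aryl Ether Variation in a Bile Acid Receptor Agonist Series

A few compounds are considered here, and "the series" means these few. Any claim that something is new, unique, unknown or untested is made for them only; others in the source may bear on it.

Three compounds have been measured in an assay on isolated protein for agonist activity at Bile acid receptor (Homo sapiens), read by AlphaScreen, with a stated time of 30 min; on this read-out lower numbers stand for an effect already at smaller amounts and higher numbers for an effect only at larger amounts of compound:

Compound 1, `COc1ccc(Oc2ccc([C@H]3S[C@@H](C)C(=O)Nc4c3c(C)nn4-c3ccccc3C)cc2)cc1`: 2200 nM
Compound 2, `CCOc1cccc(-c2ccc([C@H]3S[C@@H](C)C(=O)Nc4c3c(C)nn4-c3ccccc3C)cc2)c1`: 3500 nM
Compound 3, `Cc1nn(-c2ccccc2C(C)C)c2c1[C@@H](c1ccc(Oc3ccccc3)cc1)S[C@@H](C)C(=O)N2`: 1900 nM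

Compound 2 carries the highest of the three numbers, but its nearest neighbour, compound 1, differs from it by a 1.6-fold higher number from compound 1 to compound 2 (0.20 log units; within the scatter), and compound 3 sits no further away, so the three values cannot be told apart in this assay .

The next compound, compound 4, `COc1cccc(Oc2ccc([C@H]3S[C@@H](C)C(=O)Nc4c3c(C)nn4-c3ccccc3C)cc2)c1`, is built from compound 2 by the change (3-methoxyphenoxy in place of 3-ethoxyphenyl on an aromatic carbon). For the measured compounds named here, the only measured step that bears on it is the one between compound 1 and compound 2, where a 1.6-fold higher number from compound 1 to compound 2 (0.20 log units; within the scatter) went along with a phenoxy-type group giving way to a directly attached substituted phenyl; compound 4 brings an aryl ether of the same kind back, carrying a methoxy in the manner named above. Compound 3, also an aryl ether, shows a value in the same range as compound 1. A step back toward the values of compound 1 and compound 3 is therefore expected, and the estimated step of a 1.5-fold lower number from compound 2 to compound 4 (0.16 log units; within the scatter) is not expected to exceed the scatter. Compound 4 is estimated at 2400 nM in this assay , with a likely range from 1000 nM to 6000 nM.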

Compound 4, half-maximal effective concentration: 1700 nM
Estimate against measurement, compound 4: 1.4-fold (0.15 log units) above; the range from low to high includes it.
By their numbers in this assay, from the lowest: compounds 4, 3, 1 and 2 (each within the scatter of the next, the first and the last beyond it).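

In this assay, 3-methoxyphenoxy in place of 3-ethoxyphenyl, on an aromatic carbon para to a large group, gives a 2.1-fold lower number from compound 2 to compound 4 (0.31 log units; beyond the scatter), a modest step and the first here to lie beyond the scatter, whereas the earlier exchange of 3-ethoxyphenyl for 4-methoxyphenoxy gave a 1.6-fold higher number from compound 1 to compound 2 (0.20 log units; within the scatter). The two aryl ethers cannot be told apart, as 3-methoxyphenyl in place of 4-methoxyphenyl on the oxygen gives a 1.3-fold lower number from compound 1 to compound 4 (0.11 log units; within the scatter), so the methoxy can stand in either of these two arrangements without a readable change in this assay. Nothing available bears on the reason for the step from the 3-ethoxyphenyl group to the 3-methoxyphenoxy group.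

The step exchanges the ethoxy for a methoxy and also adds the oxygen on the aromatic carbon, and the compounds shown do not separate these two parts of the change. From the compounds shown here alone, it also remains open how the series would respond to an amine or a carboxylic acid on the outer ring in place of the methoxy.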